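The compounds below may be only part of what the source reports. "The series", "measured", "known", "first", "only" and "open" are said of these compounds alone.

Measured so far:
Compound 1, `CCC(C)(C)Cc1c[nH]c(CCc2ccc(-n3ncnn3)cc2)n1`, gives in a functional assay on HEK293 cells for agonist activity at Bombesin receptor subtype-3 (Mus musculus), read by luminescence and calcium flux, with a stated time of 10 min (on this read-out higher numbers stand for an effect only at larger amounts of compound and lower numbers for an effect already at smaller amounts), a value of 99 nM.
Compound 2, `CCC(C)(C)Cc1c[nH]c(CCc2ccc(-c3cccc(C#N)n3)cc2)n1`, gives in this assay a value of 115 nM.

Going by the values given here, compound 2 holds the higher of these two numbers, yet the single measured step, a 1.2-fold higher number from compound 1 to compound 2 (0.07 log units; within the scatter), stays within the scatter, so the two compounds cannot be told apart. Compound 3, `CCC(C)(C)Cc1c[nH]c(CCc2ccc(-c3ccc(F)cn3)cc2)n1`, differs from compound 2 by 5-fluoropyridin-2-yl in place of 6-cyanopyridin-2-yl on an aromatic carbon. Among the compounds with values here, the one step on record also exchanged the aromatic group at this same place and moved nothing beyond the scatter; no step beyond the scatter is therefore expected in this assay. Compound 3 is estimated at 120 nM, within a range from 40 nM to 400 nM. The expected step is a 1.0-fold higher number from compound 2 to compound 3 (0.02 log units; within the scatter).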

Compound 3, half-maximal effective concentration: 105 nM
For compound 3 the middle estimate is 1.1-fold (0.06 log units) above the measured one; the measured number falls inside the stated range.
By their numbers in this assay, from the lowest: compounds 1, 3 and 2 (each within the scatter of the next).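

With a third aromatic group at this place, para to a large group, both a 1.1-fold lower number from compound 2 to compound 3 (0.04 log units; within the scatter) and a 1.1-fold higher number from compound 1 to compound 3 (0.03 log units; within the scatter) stay within the scatter in this assay and so cannot be read as real changes. The three compounds therefore cannot be told apart, even though 5-fluoropyridin-2-yl carries a fluorine and lacks the nitrile of 6-cyanopyridin-2-yl. No measurement at hand explains this sameness. Still open, on these data alone, is whether a group of another kind here, such as an amine, a carboxylic acid or a longer alkyl chain, would keep the number in this range.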